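The source may hold more compounds than are shown below. What is called first, only, known or untested is meant among the compounds shown, and "the series" means these compounds.

Measured compounds in an ADME assay on microsomes from liver (Mus musculus) for metabolic stability, read by HPLC, using NADPH, with a stated time of 60 min, tested at 1 uM, in the presence of a further agent that is not named here; on this read-out higher numbers stand for fast clearance and lower numbers for slow clearance:
- compound 1 `O=C(NNS(=O)(=O)c1ccccc1F)c1cc(F)cc(-c2ccccn2)c1`: 131 uL/min
- compound 2 `Cc1cc(-n2cccn2)cc(C(=O)NNS(=O)(=O)c2ccccc2)c1F`: 567 uL/min
- compound 3 `CCOc1cc(C)cc(C(=O)NNS(=O)(=O)c2ccccc2F)c1`: > 866 uL/min, a limit of the assay rather than a number

Among the two numbers in hand, compound 2 stands highest in this assay. Compound 1 gives the lower number, and the gap between compound 1 and compound 2 is beyond the usual scatter of this read-out. The value of compound 3 in this assay is a limit and is treated as such, not as a number. All three share the sulfonyl hydrazide core; they differ in the substituents on the benzoyl ring.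

Compound 4 `C=CCOc1cc(C)c(F)c(C(=O)NNS(=O)(=O)c2ccccc2)c1` has not yet been measured in this assay. It differs from compound 2 in one place: allyloxy in place of 1H-pyrazol-1-yl on an aromatic carbon. Within the data shown here, no pair of measured compounds differs in a single place, so no measured step guides this change directly.

The expectation for compound 4 in this assay is a step upward, of a size somewhat beyond the scatter, so that a 1.5-fold higher number from compound 2 to compound 4 (0.18 log units; within the scatter) is estimated, given that compound 3 already sits at the limit of > 866 uL/min in this assay, at which 1 of the 3 values shown sits. Compound 4 is therefore estimated at 850 uL/min, within a range from 450 uL/min to 1500 uL/min, with a fair chance that only a limit is reported.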

Compound 4, intrinsic clearance in a liver preparation (reported as CLH), per the amount of preparation that the assay uses: > 866 uL/min
Compound 4 was reported as a limit (the forecaster's own chance of this, stated with the estimate: 45%); middle value at least 1.0-fold (0.00 log units) away from the limit.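

In this assay, among these compounds, allyloxy in place of 1H-pyrazol-1-yl on an aromatic carbon gives an at least 1.5-fold higher number from compound 2 to compound 4 (0.18 log units; that floor lies within the scatter), the first single-place step, and it shows that this change at this position does not bring the read-out down. For compound 4, > 866 uL/min is a limit of the assay and not a number. The step can therefore be read only as a floor with no upper end, and the ceiling of the read-out now takes in more of the series: the limit of > 866 uL/min in this assay, at which 2 of the 4 values shown sit.

From the compounds shown here alone, whether a propoxy chain, an amine or a carboxylic acid on this aromatic carbon would give a number clear of the limit remains open. Going by these compounds, how much of the true step from 1H-pyrazol-1-yl to allyloxy lies beyond its floor also stays unknown, and so does whether the same change would act alike on the core of compound 1.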